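Swapping the aryl group on the piperazine nitrogen for pyrazinyl

The source may report more compounds than this note shows. Statements on the series, on what has been measured and on what is new or still open speak of the compounds shown alone.

Measured so far:
compound 1 `Nc1ccccc1NC(=O)c1ccc(CSC(=S)N2CCN(c3ccc(F)cc3)CC2)cc1`: 48.7%
compound 2 `Nc1ccccc1NC(=O)c1ccc(CSC(=S)N2CCN(Cc3ccccc3)CC2)cc1`: 19.7%
compound 3 `Nc1ccccc1NC(=O)c1ccc(CSC(=S)N2CCN(c3ccccc3F)CC2)cc1`: 86.4%

These three compounds share a core and differ only in the group on the ring nitrogen of the piperazine. In a functional assay on MGC-803 cells (Homo sapiens) for antiproliferative activity, read by CCK-8 assay, with a stated time of 72 h, tested at 8 uM (on this read-out higher numbers stand for a stronger effect at the one concentration tested and lower numbers for a weaker effect), compound 3 gives the highest of the three numbers; the nearest is compound 1, and the furthest is compound 2. The two steps that end at compound 3 both concern this same nitrogen: a number 37.7 percentage points higher from compound 1 to compound 3 (beyond the scatter) and a number 66.7 percentage points higher from compound 2 to compound 3 (beyond the scatter). Compound 4 `Nc1ccccc1NC(=O)c1ccc(CSC(=S)N2CCN(c3cnccn3)CC2)cc1` is the unmeasured partner, and its change from compound 3 is pyrazin-2-yl in place of 2-fluorophenyl on an amine nitrogen in a ring. Among the measured compounds shown here, no measured step involves a heteroaromatic ring at this position, so the size of the effect is open. Because compound 3 stands at 86.4% and both known changes at this nitrogen were large, a move away from the best group is expected to cost activity, with a modest downward step a number 28.4 percentage points lower from compound 3 to compound 4 (beyond the scatter) expected in this assay. Compound 4 is therefore estimated at 58%, within a range from 25% to 85%.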

Compound 4, a percentage reported as inhibition, at one concentration (the size of the read-out at that concentration, not a potency): 80.5%
Estimate against measurement, compound 4: 22.5 percentage points below; the measured number falls inside the stated range.
By their numbers in this assay, from the lowest: compound 2; then compound 1; then compounds 4 and 3 (each within the scatter of the next).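

Read in this assay, a six-membered aromatic ring with 2 hetero atoms on this amine nitrogen in a ring cannot be told apart from the carbon-only ring of 2-fluorophenyl (a number 5.9 percentage points lower from compound 3 to compound 4 (within the scatter)), so fluorine on the ring is not required for a high number here. Pyrazin-2-yl also stands clear of the two weaker groups, benzyl (a number 60.8 percentage points higher from compound 2 to compound 4 (beyond the scatter)) and 4-fluorophenyl (a number 31.8 percentage points higher from compound 1 to compound 4 (beyond the scatter)), which extends the high end of this series beyond a single fluorinated ring. Nothing available explains why these groups give the numbers they do.

The compounds shown leave open whether other nitrogen-containing rings, such as pyridin-2-yl or pyrimidin-2-yl, match pyrazin-2-yl on this nitrogen. They also leave open how a small alkyl group such as methyl, or an acetyl group, would fare at the same place.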